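Fluoro step on the benzyl group: working notes

The compounds below may be only part of what the source reports. "The series", "measured", "known", "first", "only" and "open" are said of these compounds alone.

compound 1 `Cc1ccc(S(=O)(=O)Oc2ccccc2/C=C(\C#N)C(=O)Nc2nnc(Cc3ccccc3)s2)cc1`: 16%
compound 2 `N#C/C(=C\c1ccccc1OS(=O)(=O)c1ccccc1[N+](=O)[O-])C(=O)Nc1nnc(Cc2ccccc2)s1`: 12%

Both values come from a functional assay on HL-60 cells (Homo sapiens) for inhibition, read by CCK-8 assay, with a stated time of 48 h, tested at 20 uM; a higher number here means more inhibition of growth at the concentration tested, a lower number less inhibition of growth. Among the compounds with values here, there, compound 2 gives 12%, which lies within the scatter of compound 1, the only other measured compound. The next compound, compound 3 `N#C/C(=C\c1ccccc1OS(=O)(=O)c1ccccc1[N+](=O)[O-])C(=O)Nc1nnc(Cc2ccc(F)cc2)s1`, differs from compound 2 by fluoro in place of hydrogen on an aromatic carbon; in words, fluoro in place of hydrogen on an aromatic carbon, which reads as benzyl to 4-fluorobenzyl. Within the data shown here, only one measured step is available, a number 4 percentage points lower from compound 1 to compound 2 (within the scatter), a change of 2-nitrophenyl in place of 4-methylphenyl on a sulfonyl sulfur. Among the measured compounds shown here, it stays within the scatter and lies elsewhere in the structure, so no measurement yet covers a change on the benzyl group. No step beyond the scatter is therefore expected, and the estimated step is a number 4 percentage points higher from compound 2 to compound 3 (within the scatter). For compound 3 the estimated value is 16%, with an expected range of 6% to 35%.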

Compound 3, percent growth inhibition at one concentration: 35%
Beside the measured number, compound 3's estimate is 19 percentage points below it, within the range that was stated.
By their numbers in this assay, from the lowest: compounds 2 and 1 (each within the scatter of the next); then compound 3.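

Within the data shown here, the benzyl group is the first place in this short series where a single change carries the reading beyond the scatter: in this assay fluoro in place of hydrogen on an aromatic carbon, para to a large group, gives a number 23 percentage points higher from compound 2 to compound 3 (beyond the scatter) as its step. The one earlier step, a number 4 percentage points lower from compound 1 to compound 2 (within the scatter) on the sulfonyl sulfur, stayed within the scatter, so the benzyl ring is now the only position shown to respond to a change. Nothing at hand bears on why this step raises the number.

Open, going by these compounds, is whether chloro, methoxy or an amine on the same carbon would read like fluoro. Also open, on these data alone, is whether the fluoro step holds with 4-methylphenyl in place of 2-nitrophenyl on the sulfonyl sulfur.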